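A Fluoro Step on the Weakest of Three Compounds

This account rests on a few compounds, and the source may have more. Where it says the series, first, only, none or still open, it means among the compounds named here.

In a functional assay on MCF7 cells (Homo sapiens) for cytotoxicity, read by MTT assay, with a stated time of 96 h (a higher number here means a weaker inhibitor, a lower number a stronger inhibitor), compound 2 `COc1cc(C(=O)c2cn(-c3ccccc3)cc2-c2ccc([N+](=O)[O-])cc2)cc(OC)c1OC` gives 590 nM, the highest number of the three measured compounds. Compound 1 `COc1cc(C(=O)c2cn(-c3ccccc3)cc2-c2ccccc2[N+](=O)[O-])cc(OC)c1OC` gives 49 nM, and compound 3 `COc1ccccc1-c1cn(-c2ccccc2)cc1C(=O)c1cc(OC)c(OC)c(OC)c1` gives 190 nM. Compound 4 `COc1cc(C(=O)c2cn(-c3ccc(F)cc3)cc2-c2ccc([N+](=O)[O-])cc2)cc(OC)c1OC` differs from compound 2 by fluoro in place of hydrogen on an aromatic carbon, which turns phenyl into 4-fluorophenyl. The large 12-fold higher number from compound 1 to compound 2 (1.08 log units; beyond the scatter) and the modest 3.1-fold lower number from compound 2 to compound 3 (0.49 log units; beyond the scatter) and a 3.9-fold higher number from compound 1 to compound 3 (0.59 log units; beyond the scatter) all exchange the other substituted phenyl group. None touches the phenyl that changes here, so no measured step sizes this change, and no shift beyond the scatter is expected in this assay. The expected step is a 1.2-fold lower number from compound 2 to compound 4 (0.07 log units; within the scatter). For compound 4 the estimated value is 500 nM, with an expected range of 190 nM to 1300 nM.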

Compound 4, half-maximal inhibitory concentration: 240 nM
Beside the measured number, compound 4's estimate is 2.1-fold (0.32 log units) above it, within the range that was stated.
By their numbers in this assay, from the lowest: compound 1; then compounds 3 and 4 (each within the scatter of the next); then compound 2.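

Among these compounds, the phenyl group that stayed fixed in the earlier compounds proves able to move the number in this assay: turning it into 4-fluorophenyl gives a 2.5-fold lower number from compound 2 to compound 4 (0.39 log units; beyond the scatter). A single fluorine atom on this ring, para to a large group, is therefore enough to shift the result when the 4-nitrophenyl group is present. Nothing available explains this shift. From the compounds shown here alone, it remains open whether the same change would hold alongside the 2-nitrophenyl group of compound 1 or the 2-methoxyphenyl group of compound 3. Going by these compounds, the effect of a chloro group, an amine or a carboxylic acid at this place is also open.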